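The source may report more compounds than this note shows. Statements on the series, on what has been measured and on what is new or still open speak of the compounds shown alone.

Compound 1 `Nc1cccc(-c2cn3nc(-c4cccs4)sc3n2)c1` is the starting point of this comparison. In a functional assay on L1210 cells (Mus musculus) for inhibition, read by cell counting, with a stated time of 2 days (on this read-out lower numbers stand for stronger inhibition and higher numbers for weaker inhibition), compound 1 gives only a limit, > 250000 nM, and not a number. Going by the values given here, compound 3 `C=C(Br)C(=O)Nc1cccc(-c2cn3nc(-c4cccs4)sc3n2)c1`, its (1-bromoethenyl)carbonyl derivative, gives 170 nM in this assay; the step of an at least 1400-fold lower number from compound 1 to compound 3 (3.16 log units; beyond the scatter) is the only measured step from compound 1, and it concerns a different part of the structure. Compound 2 `COc1ccc(-c2nn3cc(-c4cccc(N)c4)nc3s2)cc1OC`, which carries another aromatic group on the shared core, gives 16000 nM in this assay. Compound 4 `Nc1cccc(-c2cn3nc(-c4ccc(Cl)cc4)sc3n2)c1` differs from compound 1 by 4-chlorophenyl in place of thiophen-2-yl on an aromatic carbon. Among the compounds with values here, no measured step bears on this exchange; the value of compound 2, 16000 nM, shows only that a different aromatic group on the shared core can yield a number rather than a limit. Compound 4 is therefore expected in this assay to sit near 50000 nM, between 8000 nM and 250000 nM, an expected step of an at least 5.0-fold lower number from compound 1 to compound 4 (0.69 log units; beyond the scatter) of very uncertain size.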

Compound 4, half-maximal inhibitory concentration: >= 250000 nM
Compound 4 was reported as a limit; the forecaster's own chance of this, stated with the estimate: 40%; middle value at least 5.0-fold (0.69 log units) away from the limit.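

Going by these compounds alone, compound 1 and compound 4 are both reported only as limits in this assay, so no step between them can be read. The compounds shown leave open how 4-chlorophenyl in place of thiophen-2-yl changes inhibition.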